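This account rests on a few compounds, and the source may have more. Where it says the series, first, only, none or still open, it means among the compounds named here.

Compound 3 `CC(C)CCSc1cc(C(F)(F)F)ccc1CNC(=O)C(C)c1ccc(NS(C)(=O)=O)c(F)c1` gives 1.4 nM in an assay on CHO cells for antagonist activity at transient receptor potential cation channel subfamily V member 1 (Homo sapiens), read by FLIPR; a lower number here means a stronger inhibitor, a higher number a weaker inhibitor. It stands highest of the three numbers recorded so far: compound 1 `CCCN(CCC)c1cc(C(F)(F)F)ccc1CNC(=O)C(C)c1ccc(NS(C)(=O)=O)c(F)c1` gives 0.3 nM and compound 2 `CC1CCN(c2cc(C(F)(F)F)ccc2CNC(=O)C(C)c2ccc(NS(C)(=O)=O)c(F)c2)CC1` gives 0.9 nM. The step of a 4.7-fold higher number from compound 1 to compound 3 (0.67 log units; beyond the scatter) is beyond the scatter, whereas a 1.6-fold higher number from compound 2 to compound 3 (0.19 log units; within the scatter) is within it, so compound 2 and compound 3 cannot be ordered against each other.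

Compound 4 `CC(C(=O)NCc1ccc(C(F)(F)F)cc1C1CCCCC1)c1ccc(NS(C)(=O)=O)c(F)c1` differs from compound 3 at one site: cyclohexyl in place of isopentylsulfanyl on an aromatic carbon.

Going by the values given here, no measured pair changes this site in the same way, so only indirect guidance exists. The two steps that do alter this site, a 3.0-fold higher number from compound 1 to compound 2 (0.48 log units; beyond the scatter) and a 4.7-fold higher number from compound 1 to compound 3 (0.67 log units; beyond the scatter), were both modest, and the exchange of one six-heavy-atom group for another, a 1.6-fold higher number from compound 2 to compound 3 (0.19 log units; within the scatter), stayed within the scatter. The series thus tolerates varied groups at this position with only small shifts. The cyclohexyl of compound 4 is a six-membered ring like the 4-methylpiperidin-1-yl of compound 2, which gave 0.9 nM, so a number near compound 2 and compound 3 is expected.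

For compound 4 the expected step is a 1.2-fold lower number from compound 3 to compound 4 (0.07 log units; within the scatter), most likely within the scatter. Compound 4 is estimated at 1.2 nM, with a range from 0.4 nM to 4 nM in this assay.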

Compound 4, inhibition constant: 0.6 nM
Compound 4: middle estimate off by 2.0-fold (0.30 log units), on the high side; low and high end bracket the measured number.
By their numbers in this assay, from the lowest: compounds 1, 4, 2 and 3 (each within the scatter of the next, the first and the last beyond it).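

In this assay, replacing isopentylsulfanyl with cyclohexyl keeps the heavy-atom count the same but exchanges an open chain carrying sulfur for a ring of carbon only, and this gives a change beyond the scatter (a 2.3-fold lower number from compound 3 to compound 4 (0.37 log units; beyond the scatter)), so the position responds to more than the size of the group. Cyclohexyl, with no hydrogen-bond acceptor, cannot be separated from either nitrogen-linked group (a 1.5-fold lower number from compound 2 to compound 4 (0.18 log units; within the scatter); a 2.0-fold higher number from compound 1 to compound 4 (0.30 log units; within the scatter)), which shows that a nitrogen on this aromatic carbon is not required for a number in this range. No measurement on hand accounts for the difference between cyclohexyl and isopentylsulfanyl.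

The compounds shown do not separate the effect of the ring from that of losing the sulfur: an isopentyl chain and a cyclohexylsulfanyl group on this carbon would tell these two changes apart. As far as these compounds go, how far the tolerance at this position extends also remains open, since every group here is a large, uncharged one, and a methyl, a phenyl ring, a primary amine or a carboxylic acid would test its limits.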